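This account rests on a few compounds, and the source may have more. Where it says the series, first, only, none or still open, it means among the compounds named here.

Measured so far in an ADME assay on Huh-7 cells (Homo sapiens) for cytotoxicity, read by a luciferase reporter and WST assay, with a stated time of 3 days; a lower number here means that less compound is tolerated, a higher number that more compound is tolerated:
Compound 1 `Cc1ccc(-c2cc(NO)c(C(=O)Nc3ccccc3)c(=O)o2)cc1` gives > 20000 nM, which is a limit of the assay.
Compound 2 `COc1ccc(-c2cc(NO)c(C(=O)Nc3ccccc3)c(=O)o2)cc1` gives 16200 nM.
Compound 3 `Cc1ccc(-c2cc(NO)c(C(=O)NCc3ccccc3)c(=O)o2)cc1` gives > 20000 nM, again a limit of the assay.

Two of these three values sit at the limit of > 20000 nM in this assay, at which 2 of the 3 values shown sit. Putting a methoxy in place of the methyl, (methoxy in place of methyl on an aromatic carbon), produced an at least 1.2-fold lower number from compound 1 to compound 2 (0.09 log units; that floor lies within the scatter). The core of compound 3 differs from the core of compound 1 in one respect, (benzyl in place of phenyl on an amide-type nitrogen), and the size of that change is a step that the two limits leave unreadable from compound 1 to compound 3. Compound 4 `COc1ccc(-c2cc(NO)c(C(=O)NCc3ccccc3)c(=O)o2)cc1` has not yet been measured; it arises from compound 3 by the same change as before, (methoxy in place of methyl on an aromatic carbon). Because an at least 1.2-fold lower number from compound 1 to compound 2 (0.09 log units; that floor lies within the scatter) was small, the step expected for compound 4 is an estimated at least 1.1-fold lower number from compound 3 to compound 4 (0.07 log units; that floor lies within the scatter). Compound 4 is therefore expected at about 17000 nM, estimated between 9000 nM and 30000 nM, with a fair chance that this assay again returns only a limit.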

Compound 4, half-maximal cytotoxic concentration: > 20000 nM
Compound 4: a limit, no number (the forecaster's own chance of this, stated with the estimate: 50%); middle value at least 1.1-fold (0.07 log units) away from the limit.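

In this assay compound 4 gives > 20000 nM, which is a limit of the assay. Within the data shown here, the step of methoxy in place of methyl on this benzyl amide core cannot be read because both of its ends are limits: the limit of > 20000 nM in this assay, at which 3 of the 4 values shown sit. The only readable new comparison concerns the benzyl in place of phenyl change, with an at least 1.2-fold higher number from compound 2 to compound 4 (0.09 log units; that floor lies within the scatter), so the result neither shows that the methoxy change carries from the core of compound 1 to the core of compound 3 nor shows that it fails to carry.

On these data alone, the actual tolerated concentrations of compound 3 and compound 4 remain open, so the two methoxy steps cannot be compared. Also open, as far as these compounds go, is whether an amine or a carboxylic acid in place of the methoxy would give a readable value on either core.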